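A few compounds are considered here, and "the series" means these few. Any claim that something is new, unique, unknown or untested is made for them only; others in the source may bear on it.

Of the compounds shown here, two have been measured in an ADME assay on RAW264.7 cells (Mus musculus) for cytotoxicity, read by MTT assay, with a stated time of 72 h, tested at 50 ug/mL; a lower number here means less inhibition, a higher number more inhibition at the concentration tested (going by the name of the read-out). Compound 1 `O=C(c1nc2cc(C(F)(F)F)ccc2s1)N1CCN(c2cnccn2)CC1` gives 28.1%. Within the data shown here, compound 2 `COc1ccc(N2CCN(C(=O)c3nc4cc(C(F)(F)F)ccc4s3)CC2)cc1` gives 19.4%, the lowest of the two numbers, with compound 1 the nearest; the one step between them, a number 8.7 percentage points lower from compound 1 to compound 2 (within the scatter), came with 4-methoxyphenyl in place of pyrazin-2-yl on an amine nitrogen in a ring, and it stays within the scatter.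

Compound 3 `CC(=O)c1ccc(N2CCN(C(=O)c3nc4cc(C(F)(F)F)ccc4s3)CC2)cc1` is not yet measured. It differs from compound 2 as follows: acetyl in place of methoxy on an aromatic carbon. Among the measured compounds shown here, no measured step exchanges one group for another on the six-membered aromatic ring of carbon only; the single step recorded, a number 8.7 percentage points lower from compound 1 to compound 2 (within the scatter), exchanged a whole ring on the amine nitrogen and bears on this change only in showing that the one variation tried at that end of the molecule stayed within the scatter. Compound 3 is therefore expected to stay near compound 2, with the step of a number 2.6 percentage points higher from compound 2 to compound 3 (within the scatter) estimated as no change beyond the scatter. The estimate for compound 3 in this assay is 22%, between 8% and 36%.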

Compound 3, a percentage reported as inhibition, at one concentration (the size of the read-out at that concentration, not a potency): 30.6%
Compound 3: middle estimate off by 8.6 percentage points, on the low side, and the stated range covers the measured number.
By their numbers in this assay, from the lowest: compounds 2, 1 and 3 (each within the scatter of the next, the first and the last beyond it).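

In this assay, the exchange of methoxy for acetyl on an aromatic carbon, para to a large group, gives a number 11.2 percentage points higher from compound 2 to compound 3 (beyond the scatter); this is the only step shown beyond the scatter, so the group at this place on the ring can shift the read-out, if only modestly. The exchange of pyrazin-2-yl for 4-acetylphenyl on the amine nitrogen gives a number 2.5 percentage points higher from compound 1 to compound 3 (within the scatter) and leaves compound 1 and compound 3 indistinguishable, so an aryl group on that nitrogen does not by itself separate the compounds, and 4-methoxyphenyl is separated only from 4-acetylphenyl, not from pyrazin-2-yl. There is no evidence here on what lies behind the difference between acetyl and methoxy.

On these data alone, whether a nitrile, a carboxylic acid or an amine at the same place would read with acetyl or with methoxy remains open, as does the reading of a plain phenyl ring with hydrogen there. As far as these compounds go, all the numbers come from a single concentration, so whether the step between methoxy and acetyl persists at other concentrations also remains open.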